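Urea series on ACHN cells: low toxicity so far

The source may report more compounds than this note shows. Statements on the series, on what has been measured and on what is new or still open speak of the compounds shown alone.

Going by the values given here, compound 1 `O=C(Nc1cccc(-n2cc(-c3ccncc3)c(-c3ccc(Cl)c(O)c3)n2)c1)Nc1cccc(C(F)(F)F)c1` and compound 2 `COc1cc(-c2nn(-c3cccc(NC(=O)Nc4cc(C(F)(F)F)cc(C(F)(F)F)c4)c3)cc2-c2ccncc2)ccc1Cl` are the two measured members. In a functional assay on ACHN cells (Homo sapiens) for inhibition, read by sulforhodamine B assay, with a stated time of 48 h (on this read-out higher numbers stand for lower toxicity in this test and lower numbers for higher toxicity in this test), compound 1 gives only a limit of > 32500 nM. Compound 2 likewise returns only a limit, > 50000 nM, in this assay. Among the compounds with values here, compound 2 therefore stands at the edge of what the assay reports: no number, and the two measured members cannot be ordered against one another (the limit of > 32500 nM in this assay, at which 1 of the 2 values shown sits, (the limit of > 50000 nM in this assay, at which 1 of the 2 values shown sits)).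

Compound 3 `O=C(Nc1cccc(-n2cc(-c3ccncc3)c(-c3ccc(Cl)c(O)c3)n2)c1)Nc1cc(C(F)(F)F)cc(C(F)(F)F)c1` is not yet measured. It differs from compound 2 by hydrogen in place of methyl on an oxygen on an aromatic ring. The same hydroxy group is carried by compound 1, which also gives only a limit in this assay. Within the data shown here, no measured step shows a change beyond the scatter, so none is expected here.

The expected step that the limit leaves unreadable from compound 2 to compound 3 is none beyond the scatter. Compound 3 is expected at 60000 nM, between 30000 nM and 120000 nM, most likely again reported only as a limit.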

Compound 3, concentration lethal to 50% of the cells: 17300 nM
Estimate against measurement, compound 3: 3.5-fold (0.54 log units) above, outside the stated range (below it).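

Methoxy to hydroxy on the 4-chloro-3-methoxyphenyl group gives an at least 2.8-fold lower number from compound 2 to compound 3 (0.46 log units; beyond the scatter), so in this assay this place on the aromatic ring responds to the change, which neither earlier compound could show. With hydroxy present in both compounds, trifluoromethyl in place of hydrogen gives an at least 1.8-fold lower number from compound 1 to compound 3 (0.27 log units; that floor lies within the scatter), and this floor does not establish a real difference, so hydroxy alone cannot yet be separated from the second trifluoromethyl as the condition for the lower number. The first step is only a floor, because compound 2 carries only a limit: the limit of > 50000 nM in this assay, at which 1 of the 3 values shown sits.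

As far as these compounds go, the true size of the trifluoromethyl step stays open, because compound 1 carries only a limit: the limit of > 32500 nM in this assay, at which 1 of the 3 values shown sits. Also open is whether an amine or an ethoxy group on the same oxygen-bearing ring carbon would behave like hydroxy or like methoxy.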